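Fluoro for trifluoromethyl: clearance notes on compound 4

The source may hold more compounds than are shown below. What is called first, only, known or untested is meant among the compounds shown, and "the series" means these compounds.

In an in vitro ADME assay on microsomes from liver (Mus musculus) for pharmacokinetics, read by LC-MS (a higher number here means faster removal of the compound, a lower number slower removal), compound 1 `Cc1ccc2nc(C)n(-c3ccc(C(=O)NC4CC4)s3)c2c1` gives > 72 mL/min/kg, which is a limit of the assay and not a number. Compound 2 `Cc1nc2ccc(OC(F)(F)F)cc2n1-c1ccc(C(=O)NC2CC2)s1` gives 41 mL/min/kg and compound 3 `Cc1nc2ccc(C(F)(F)F)cc2n1-c1ccc(C(=O)NC2CC2)s1` gives 68 mL/min/kg, and these two values lie within the scatter of each other. Compound 3 therefore stands level with compound 2 on the numbers available.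

Compound 4 `Cc1nc2ccc(F)cc2n1-c1ccc(C(=O)NC2CC2)s1` carries fluoro in place of trifluoromethyl on an aromatic carbon of the six-membered aromatic ring of carbon only (fluoro in place of trifluoromethyl on an aromatic carbon). For the measured compounds named here, no measured compound yet carries fluoro, so the nearest guidance comes from the other exchanges on an aromatic carbon. These are an at least 1.0-fold lower number from compound 1 to compound 3 (0.02 log units; that floor lies within the scatter), an at least 1.7-fold lower number from compound 1 to compound 2 (0.24 log units; that floor lies within the scatter) and a 1.7-fold higher number from compound 2 to compound 3 (0.22 log units; within the scatter). All three stay within the scatter, although the first two are floors and not full sizes.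

No step beyond the scatter is therefore expected in this assay, and the direction is left open, with a slight lean towards a lower number. The estimated size is a 1.2-fold lower number from compound 3 to compound 4 (0.07 log units; within the scatter). The estimate for compound 4 is 58 mL/min/kg. The expected range for compound 4 runs from 30 mL/min/kg to 85 mL/min/kg, and a result reported only as a limit would not be a surprise.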

Compound 4, clearance: > 72 mL/min/kg
Compound 4: a limit, no number (the forecaster's own chance of this, stated with the estimate: 25%); at least 1.2-fold (0.09 log units) between middle value and limit.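

In this assay, compound 4 ends at a limit of the assay and not a number, as compound 1 does, so at this aromatic carbon fluoro and methyl give no number, while trifluoromethyl and trifluoromethoxy do. The exchange for trifluoromethyl gives an at least 1.0-fold higher number from compound 3 to compound 4 (0.02 log units; that floor lies within the scatter), and the exchange for trifluoromethoxy gives an at least 1.7-fold higher number from compound 2 to compound 4 (0.24 log units; that floor lies within the scatter); both are floors that lie within the scatter, so fluoro is not shown to differ from either group, though the true steps may be larger. The step that joins the two limits cannot be read, and the ceiling of the assay restricts what this position can show: the limit of > 72 mL/min/kg in this assay, at which 2 of the 4 values shown sit.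

As far as these compounds go, how far compound 1 and compound 4 lie past that limit stays open, so fluoro and methyl cannot be ordered against each other, and neither can be set firmly against trifluoromethyl or trifluoromethoxy. Also open, from the compounds shown here alone, is whether a nitrile, an amine or a carboxylic acid on this aromatic carbon would give a number clear of the limit and beyond the scatter of the values for compound 2 and compound 3.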